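The source may hold more compounds than are shown below. What is called first, only, known or untested is meant among the compounds shown, and "the series" means these compounds.

The series shares one core, shown by compound 1 `O=C(O)COc1ccc(NC(=O)COc2ccccc2)cc1F`, in which a phenoxy group is joined through an amide to an aryloxyacetic acid. For compound 1 the result in a functional assay on CHO cells for agonist activity at Free fatty acid receptor 1 (Homo sapiens), read by FLIPR (a lower number here means that less compound is needed, a higher number that more compound is needed for the effect), is "not determined" (no result reported). Its two neighbours vary the carbon between the phenoxy oxygen and the carbonyl: compound 2 `CC(Oc1ccccc1)C(=O)Nc1ccc(OCC(=O)O)c(F)c1` carries one methyl there, and in this assay compound 2 gives 135 nM. Compound 3 `CC(C)(Oc1ccccc1)C(=O)Nc1ccc(OCC(=O)O)c(F)c1` carries two methyls on that carbon, and for compound 3 the outcome in this assay is "not determined" (no result reported). Among the measured compounds shown here, compound 2 is therefore the only member of the set with a number, and it is the anchor for anything said about the others.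

Compound 4 `Cc1cccc(OCC(=O)Nc2ccc(OCC(=O)O)c(F)c2)c1` keeps the unbranched linker of compound 1 and differs from it by methyl in place of hydrogen on an aromatic carbon. For the measured compounds named here, no pair with a measured step exists here, so the size of the change from compound 1 to compound 4 in this assay cannot be read off; the expectation is a step that stays within the usual scatter, with no clear direction. Resting on compound 2 and its 135 nM as the nearest measured relative, compound 4 is estimated at 150 nM, with a range from 40 nM to 600 nM.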

Compound 4, half-maximal effective concentration: 108 nM
Compound 4: the middle estimate sits 1.4-fold (0.14 log units) above what was measured; low and high end bracket the measured number.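

In this assay no new step can be read for compound 4, as its one-place partner compound 1 gives "not determined" (no result reported) and offers no number to compare. The compounds shown leave open how adding methyl to the phenyl ring or to the linker carbon changes the result. No further data bear on this result.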